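This account rests on a few compounds, and the source may have more. Where it says the series, first, only, none or still open, it means among the compounds named here.

Compound 1 `O=C(CCC1=CCN(CCCc2ccc(Br)cc2)C1=O)NO` in a functional assay on NUGC-3 cells (Homo sapiens) for inhibition, read by sulforhodamine B assay (a lower number here means a stronger inhibitor of growth, a higher number a weaker inhibitor of growth), gives 2200 nM. Compound 2 `CC(C)(C)c1ccc(CCCN2CC=C(CCC(=O)NO)C2=O)cc1` gives 2200 nM, level with compound 1 at the digits shown, and the two together hold the highest numbers of the three measured compounds. Compound 3 `CC(C)(C)c1ccc(CN2CC=C(CCC(=O)NO)C2=O)cc1` gives 720 nM, the lowest number of the set and beyond the scatter from compound 1.

The step to compound 4 `Cc1cccc(CCCN2CC=C(CCC(=O)NO)C2=O)c1` is 3-methylphenyl in place of 4-bromophenyl on a saturated chain carbon, three bonds along the chain from an amide-type nitrogen in a ring. Within the data shown here, the only measured step that bears on it is no change at the digits printed from compound 1 to compound 2 (within the scatter), which also swaps the substituent on the aromatic ring while the rest of the molecule stays the same; that step stayed within the scatter. Compound 3 differs from compound 2 in the chain, not in the aromatic substituent, so its value is of no help here. One aromatic substituent swap without effect is thin evidence, but nothing points the other way.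

For compound 4, therefore, the expected step is no change at the digits printed from compound 1 to compound 4 (within the scatter), that is no change beyond the scatter; the estimated value is 2200 nM with a range of 1000 nM to 4800 nM.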

Compound 4, concentration for 50% growth inhibition: 2200 nM
The estimate for compound 4 equals the measured number at the digits printed, within the range that was stated.
By their numbers in this assay, from the lowest: compound 3; then compounds 1, 2 and 4 (each within the scatter of the next).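

In this assay, no change at the digits printed from compound 1 to compound 4 (within the scatter), so this position tolerates 3-methylphenyl in place of 4-bromophenyl with no shift beyond the scatter. The earlier step, no change at the digits printed from compound 1 to compound 2 (within the scatter), covered only tert-butyl in place of bromo; the new step shows that, within these compounds, the growth-inhibition number does not depend on the bromine and holds for a second, different aryl replacement. No supporting data on why the number stays flat across these aromatic groups are available here.

Still open, from the compounds shown here alone, is whether an aromatic ring bearing an amine or a carboxylic acid would stay within the scatter as well. Also open, going by these compounds, is whether 3-methylphenyl would follow the tert-butyl-bearing compound 3, at 720 nM, on that compound's chain.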